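Difluorophenyl Replaces Dimethoxyphenyl on a Chalcone-Pyrazole Core

The compounds below may be only part of what the source reports. "The series", "measured", "known", "first", "only" and "open" are said of these compounds alone.

Compound 1 `COc1cc(-c2cc(/C=C/C(=O)c3ccc(Cl)c(Cl)c3)[nH]n2)cc(OC)c1OC`: 530 nM
Compound 2 `COc1ccc(C(=O)/C=C/c2cc(-c3cc(OC)c(OC)c(OC)c3)n[nH]2)cc1OC`: 240 nM

In a functional assay on RPMI-8226 cells (Homo sapiens) for inhibition, read by sulforhodamine B assay, with a stated time of 48 h (on this read-out lower numbers stand for stronger inhibition of growth and higher numbers for weaker inhibition of growth), compound 2 gives the lowest of the two numbers, with compound 1 the nearest at 530 nM. Compound 3 `COc1cc(-c2cc(/C=C/C(=O)c3ccc(F)c(F)c3)[nH]n2)cc(OC)c1OC` differs from compound 2 by 3,4-difluorophenyl in place of 3,4-dimethoxyphenyl on a carbonyl carbon. Within the data shown here, the only measured step bearing on this change is a 2.2-fold lower number from compound 1 to compound 2 (0.34 log units; beyond the scatter), where a dihalophenyl gave way to the dimethoxyphenyl. Returning to a dihalophenyl is therefore expected to move the number back toward that of compound 1, giving a 1.9-fold higher number from compound 2 to compound 3 (0.27 log units; within the scatter) in this assay. Compound 3 is estimated at 450 nM, within 200 nM to 1000 nM.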

Compound 3, concentration for 50% growth inhibition: 1760 nM
Beside the measured number, compound 3's estimate is 3.9-fold (0.59 log units) below it; the whole stated range lies below it.
By their numbers in this assay, from the lowest: compound 2; then compound 1; then compound 3.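

In this assay, the aryl group on the carbonyl carbon proves to matter more than the earlier pair showed: 3,4-difluorophenyl in place of 3,4-dimethoxyphenyl gives a 7.3-fold higher number from compound 2 to compound 3 (0.87 log units; beyond the scatter) and makes a wider step than the one seen before. The two dihalophenyl groups are not interchangeable either, as the change from 3,4-dichlorophenyl to 3,4-difluorophenyl gives a 3.3-fold higher number from compound 1 to compound 3 (0.52 log units; beyond the scatter) in the same direction. Nothing available here accounts for these differences.

The compounds shown leave open whether both methoxy groups are needed. As far as these compounds go, how a phenyl carrying a single methoxy, a hydroxyl or an amine would rank also remains unknown.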